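Methoxy for Fluoro on the Anilide of Compound 3

This account rests on a few compounds, and the source may have more. Where it says the series, first, only, none or still open, it means among the compounds named here.

Compound 1, `COc1ccc(Oc2ccc([N+](=O)[O-])cc2C(=O)Nc2ccc(Cl)cc2)cc1`, gives 10100 nM in a functional assay (Homo sapiens) for inhibition, using a membrane potential dye, in the presence of a further agent that is not named here; on this read-out higher numbers stand for weaker inhibition and lower numbers for stronger inhibition.
Compound 2, `COc1ccc(NC(=O)c2cc(C#N)ccc2Oc2ccc(OC)cc2)cc1`, gives 2500 nM in this assay.
Compound 3, `COc1ccc(Oc2ccc([N+](=O)[O-])cc2C(=O)Nc2ccc(F)cc2)cc1`, gives 7200 nM in this assay.

Compound 3 stands second highest of the three numbers. Its step from compound 1, a 1.4-fold lower number from compound 1 to compound 3 (0.15 log units; within the scatter), lies within the scatter, while compound 2 sits lower by a gap beyond the scatter. Compound 4, `COc1ccc(NC(=O)c2cc([N+](=O)[O-])ccc2Oc2ccc(OC)cc2)cc1`, differs from compound 3 by methoxy in place of fluoro on an aromatic carbon. Within the data shown here, no measured step follows this same change: the only step available, a 1.4-fold lower number from compound 1 to compound 3 (0.15 log units; within the scatter), swaps one halogen for another and stayed within the scatter. Compound 2 carries the methoxy on the same aryl amine but also a nitrile in place of the nitro group, so its lower number cannot be assigned to either change alone. A modest step in this assay toward a lower number is therefore expected for compound 4, with wide uncertainty. Compound 4 is estimated at 5000 nM, within 2000 nM to 12000 nM. This estimate for compound 4 means an expected step of a 1.4-fold lower number from compound 3 to compound 4 (0.16 log units; within the scatter).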

Compound 4, half-maximal inhibitory concentration: 3400 nM
For compound 4 the middle estimate is 1.5-fold (0.17 log units) above the measured one; the range from low to high includes it.
By their numbers in this assay, from the lowest: compounds 2 and 4 (each within the scatter of the next); then compounds 3 and 1 (each within the scatter of the next).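

At this position, para to a large group, the step of a 2.1-fold lower number from compound 3 to compound 4 (0.33 log units; beyond the scatter) and the step of a 3.0-fold lower number from compound 1 to compound 4 (0.47 log units; beyond the scatter) both lie beyond the scatter in this assay and are modest, whereas the exchange of one halogen for the other, the step of a 1.4-fold lower number from compound 1 to compound 3 (0.15 log units; within the scatter), did not leave the scatter. At the other changed place, the step of a 1.4-fold higher number from compound 2 to compound 4 (0.13 log units; within the scatter) stays within the scatter, so nitro in place of cyano shows no clear change with 4-methoxyphenyl present. No measured evidence among these results explains either outcome.

On these data alone, only fluoro, chloro and methoxy are compared at this position, so it remains open how an amine, a hydroxyl or a longer chain such as ethoxy would read there. As far as these compounds go, it also remains open whether methoxy in place of fluoro gives a similar step when nitrile replaces nitro.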